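Ring-nitrogen swap on the chain terminus in a promoter series

A few compounds are considered here, and "the series" means these few. Any claim that something is new, unique, unknown or untested is made for them only; others in the source may bear on it.

Measured compounds:
compound 1 `CC[N+]1(CCCCCCCOc2ccc(-n3cc(C(=O)Nc4cc(F)cc(F)c4)c(=O)c4ccc(N(C)C)nc43)cc2C)CCCCC1` 19.7%
compound 2 `CC[N+]1(CCCCCCCOc2cc(C)cc(-n3cc(C(=O)Nc4cc(F)cc(F)c4)c(=O)c4ccc(N(C)C)nc43)c2)CCCCC1` 67.2%
compound 3 `Cc1cc(-n2cc(C(=O)Nc3cc(F)cc(F)c3)c(=O)c3ccc(N(C)C)nc32)ccc1OCCCCCCC[N+]1(C)CCN(C)CC1` 16.2%

All three were read in an assay on LX2 cells for inhibition of COL1A1 promoter (Homo sapiens), read by a luciferase reporter, with a stated time of 24 h, tested at 20 uM; a lower number here means a weaker effect, a higher number a stronger effect of the compound at the concentration tested. Compound 2 gives the highest of the three numbers, and compound 1 and compound 3 sit close together. Compound 1 and compound 2 are built from the same atoms joined differently; the difference between the two cores is not broken down here.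

From compound 1 to compound 3 one change is made: a group of 8 heavy atoms (6 carbon, 2 nitrogen; one six-membered non-aromatic ring with 2 hetero atoms) in place of a group of 8 heavy atoms (7 carbon, 1 nitrogen; one six-membered non-aromatic ring with 1 hetero atom), on a saturated chain carbon, seven bonds along the chain from an oxygen on an aromatic ring. The step that goes with it is a number 3.5 percentage points lower from compound 1 to compound 3 (within the scatter), so the swap leaves the read-out where it was within the scatter.

Compound 4 `Cc1cc(OCCCCCCC[N+]2(C)CCN(C)CC2)cc(-n2cc(C(=O)Nc3cc(F)cc(F)c3)c(=O)c3ccc(N(C)C)nc32)c1` is not yet measured. It stands to compound 2 as compound 3 stands to compound 1: a group of 8 heavy atoms (6 carbon, 2 nitrogen; one six-membered non-aromatic ring with 2 hetero atoms) in place of a group of 8 heavy atoms (7 carbon, 1 nitrogen; one six-membered non-aromatic ring with 1 hetero atom), on a saturated chain carbon, seven bonds along the chain from an oxygen on an aromatic ring. The place line reads the same in both pairs, so this is the same change, made twice in the set. Going by the values given here, with only one measured instance, and that one within the scatter, the expectation for compound 4 is a step of about a number 4.2 percentage points lower from compound 2 to compound 4 (within the scatter) from compound 2, resting on the size of a number 3.5 percentage points lower from compound 1 to compound 3 (within the scatter) applied to the value of compound 2, 67.2%. Compound 4 is therefore expected to give 63% in this assay, with a range from 45% to 76%.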

Compound 4, a percentage reported as inhibition, at one concentration (the size of the read-out at that concentration, not a potency): 2.8%
Compound 4: the middle estimate sits 60.2 percentage points above what was measured; the measured number lies below the stated range.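

In this assay the ring swap on the chain terminus comes with a number 64.4 percentage points lower from compound 2 to compound 4 (beyond the scatter), so the step seen on the core of compound 1 did not carry over to the other core. The size of this change depends on the core that carries it, and the two pairs differ clearly: the same change on two cores in this assay, a number 3.5 percentage points lower (within the scatter) from compound 1 to compound 3 and a number 64.4 percentage points lower (beyond the scatter) from compound 2 to compound 4, 60.9 percentage points apart, beyond the scatter of two such steps

This rests on a single pair of pairs read at one concentration, so it shows no general rule and does not explain why the cores part. Compound 1 already gives 19.7%, and these compounds cannot tell whether that low start shapes the size of the step seen on its core.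

Open, from the compounds shown here alone, is whether the split between the two cores holds for other chain termini, such as a morpholine ring or a simple trimethylammonium group. Also open, going by these compounds, is whether it survives a shorter chain between the aromatic oxygen and the terminal ring.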